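Swapping a phenyl for thiophen-2-yl on the ketone

The compounds below may be only part of what the source reports. "The series", "measured", "known", "first", "only" and "open" are said of these compounds alone.

In a functional assay (trachea) with Rattus norvegicus as the target (on this read-out lower numbers stand for lower potency and higher numbers for higher potency (the scale is a negative logarithm)), compound 1 `COc1ccc2c(c1)C(n1ccccc1=O)=CC(C)(C)O2` gives 5.99, compound 2 `CCC(=O)c1ccc2c(c1)C(n1ccccc1=O)=CC(C)(C)O2` gives 5.85, and compound 3 `CC1(C)C=C(n2ccccc2=O)c2cc(C(=O)c3ccccc3)ccc2O1` gives 6.21, the highest of the three numbers, though its gap to compound 1 is within the scatter. Compound 4 `CC1(C)C=C(n2ccccc2=O)c2cc(C(=O)c3cccs3)ccc2O1` differs from compound 3 by thiophen-2-yl in place of phenyl on a carbonyl carbon. Among the compounds with values here, the one measured step at the carbonyl carbon is a number 0.36 log units higher from compound 2 to compound 3 (beyond the scatter); the steps of a number 0.14 log units lower from compound 1 to compound 2 (within the scatter) and a number 0.22 log units higher from compound 1 to compound 3 (within the scatter) touch the aromatic carbon instead. Nothing measured here exchanges one aromatic ring for another on that carbonyl, so the expected step in this assay, a number 0.01 log units lower from compound 3 to compound 4 (within the scatter), is none beyond the scatter. Compound 4 is therefore estimated at 6.2, between 5.8 and 6.6.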

Compound 4, logarithm of the reciprocal of the active concentration, log(1/C): 5.84
Compound 4: middle estimate off by 0.36 log units, on the high side; the range from low to high includes it.
By their numbers in this assay, from the lowest: compounds 4, 2, 1 and 3 (each within the scatter of the next, the first and the last beyond it).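

On this carbonyl carbon, the aromatic ring cannot be exchanged without consequence: in this assay the change to thiophen-2-yl gives a number 0.37 log units lower from compound 3 to compound 4 (beyond the scatter) and so cancels the advantage phenyl showed over ethyl. The remaining steps, a number 0.01 log units lower from compound 2 to compound 4 (within the scatter) and a number 0.15 log units lower from compound 1 to compound 4 (within the scatter), both lie within the scatter, so thiophen-2-yl on the carbonyl offers no measurable gain over either earlier group. No measurement offered here accounts for the difference between the two rings. Still open, as far as these compounds go, is whether a furan or pyridine ring on this carbonyl would match phenyl or thiophen-2-yl.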